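The source may report more compounds than this note shows. Statements on the series, on what has been measured and on what is new or still open speak of the compounds shown alone.

Compound 1 `N[C@@H]1CCN(c2cc3c(cc2F)c(=O)c(C(=O)O)cn3Cc2ccc(-c3ccccc3)cc2)C1` and compound 2 `CNCCCNc1cc2c(cc1F)c(=O)c(C(=O)O)cn2Cc1ccc(-c2ccccc2)cc1` share one core and differ only in the amine-bearing group on the aromatic carbon. In an assay on isolated protein for inhibition of DNA topoisomerase 1 (Homo sapiens), with a stated time of 15 min (on this read-out lower numbers stand for stronger inhibition and higher numbers for weaker inhibition), compound 1 gives 63600 nM and compound 2 gives 63600 nM, so compound 2 stands level with compound 1; the step of no change at the digits printed from compound 1 to compound 2 (within the scatter) shows that exchanging one amine group for another left the read-out where it was. Compound 3 `NC[C@@H]1CCN(c2cc3c(cc2F)c(=O)c(C(=O)O)cn3Cc2ccc(-c3ccccc3)cc2)C1` carries 3-(aminomethyl)pyrrolidin-1-yl in place of (3-(methylamino)propyl)amino on an aromatic carbon. Within the data shown here, the one step that bears on this kind of exchange was within the scatter, so the expected step of no change at the digits printed from compound 2 to compound 3 (within the scatter) is none beyond the scatter. Compound 3 is estimated at 63600 nM, with a range from 30000 nM to 135000 nM.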

Compound 3, half-maximal inhibitory concentration: 15600 nM
Estimate against measurement, compound 3: 4.1-fold (0.61 log units) above; the measured number lies below the stated range.
By their numbers in this assay, from the lowest: compound 3; then compounds 1 and 2 (each within the scatter of the next).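

The read-out in this assay does respond to the amine group at this position: 3-(aminomethyl)pyrrolidin-1-yl in place of (3-(methylamino)propyl)amino gives a 4.1-fold lower number from compound 2 to compound 3 (0.61 log units; beyond the scatter) where the earlier exchange gave no change beyond the scatter. Aminomethyl in place of amino on a saturated ring carbon gives a 4.1-fold lower number from compound 1 to compound 3 (0.61 log units; beyond the scatter) and so the ring alone does not account for the lower number, since compound 1 carries a ring too. No measurement shown gives a reason for these steps.

As far as these compounds go, whether a longer chain such as aminoethyl on that ring carbon, or a piperazine in place of the pyrrolidine, would lower the number further stays open.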